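Bromo for Methyl: What to Expect of Compound 4

A few compounds are considered here, and "the series" means these few. Any claim that something is new, unique, unknown or untested is made for them only; others in the source may bear on it.

Compounds measured so far:
- Compound 1, `Cc1ccccc1Sc1cccc(N)c1C#N`: in a functional assay on MT4 cells (Homo sapiens) for cytotoxicity (on this read-out lower numbers stand for stronger inhibition and higher numbers for weaker inhibition), compound 1 gives > 40000 nM, which is a limit of the assay.
- Compound 2, `N#Cc1c(N)cccc1Sc1ccccc1Br`: in this assay compound 2 gives 41000 nM.
- Compound 3, `Cc1ccc([S+]([O-])c2cccc(N)c2C#N)cc1`: in this assay compound 3 gives > 200000 nM, again a limit of the assay.

The difference between the core of compound 1 and the core of compound 3 is not broken down here. Compound 2 arises from compound 1 by bromo in place of methyl on an aromatic carbon. Compound 4, `N#Cc1c(N)cccc1[S+]([O-])c1ccc(Br)cc1`, arises from compound 3 by bromo in place of methyl on an aromatic carbon, the same kind of change, though the place differs: ortho to a large group in the first pair, para to a large group in the second. The measured step that the limit leaves unreadable from compound 1 to compound 2 cannot be read because compound 1 sits at the limit of > 40000 nM in this assay, at which 1 of the 3 values shown sits. Compound 3 sits at the limit of > 200000 nM in this assay, at which 1 of the 3 values shown sits, so the new step is likewise expected to stay unreadable; the step of an at least 1.3-fold lower number from compound 3 to compound 4 (0.12 log units; that floor lies within the scatter) is only an estimate. Compound 4 is expected to give about 150000 nM, between 40000 nM and 400000 nM.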

Compound 4, half-maximal inhibitory concentration: > 200000 nM
Compound 4 ended at the assay's limit; the forecaster's own chance of this, stated with the estimate: 65%; middle value at least 1.3-fold (0.12 log units) away from the limit.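

Compound 3 and compound 4 both stop at an assay limit, so no step can be read between them: the limit of > 200000 nM in this assay, at which 2 of the 4 values shown sit.

The compounds shown leave open whether in this assay bromo in place of methyl on an aromatic carbon shifts the result at all.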